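A few compounds are considered here, and "the series" means these few. Any claim that something is new, unique, unknown or untested is made for them only; others in the source may bear on it.

compound 1 `O=C1C(Nc2cccc(-c3ccccc3)c2)=CC(=O)c2ncncc21` at 5100 nM
compound 2 `O=C1C(Nc2ccc(C3CCCCC3)cc2)=CC(=O)c2ncncc21` at 500 nM
compound 3 `O=C1C(Nc2ccc(-c3cc(Cl)cc(Cl)c3)cc2)=CC(=O)c2ncncc21` at 3300 nM

These values come from a functional assay on BXPC-3 cells (Homo sapiens) for cytotoxicity, read by MTT assay, with a stated time of 72 h (a higher number here means a weaker inhibitor, a lower number a stronger inhibitor), throughout. Compound 2 has the lowest number of the three, with compound 1 and compound 3 both beyond the scatter above it. Compound 4 `O=C1C(Nc2ccc(-c3ccccn3)cc2)=CC(=O)c2ncncc21` puts pyridin-2-yl in place of cyclohexyl on an aromatic carbon, and pyridin-2-yl in place of cyclohexyl on an aromatic carbon sums up that change. Among the compounds with values here, the one measured step that also brings an aromatic ring in for cyclohexyl is modest: a 6.6-fold higher number from compound 2 to compound 3 (0.82 log units; beyond the scatter) in size. Within the data shown here, no measured compound carries pyridin-2-yl, so a higher number of similar or smaller size is expected in this assay for this change. The estimated step is a 3.6-fold higher number from compound 2 to compound 4 (0.56 log units; beyond the scatter) in size. Compound 4 is expected at 1800 nM with an estimated range from 600 nM to 5500 nM overall.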

Compound 4, half-maximal inhibitory concentration: 2700 nM
Estimate against measurement, compound 4: 1.5-fold (0.18 log units) below, and the stated range covers the measured number.
By their numbers in this assay, from the lowest: compound 2; then compounds 4, 3 and 1 (each within the scatter of the next).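

In this assay pyridin-2-yl in place of cyclohexyl gives a 5.4-fold higher number from compound 2 to compound 4 (0.73 log units; beyond the scatter) at this place on the aromatic carbon, so a second aromatic ring also stands above cyclohexyl. Pyridin-2-yl in place of 3,5-dichlorophenyl gives a 1.2-fold lower number from compound 3 to compound 4 (0.09 log units; within the scatter) and so no readable difference between these two aromatic rings. Nothing measured here gives a reason for either step. Open, on these data alone, is whether a saturated ring holding nitrogen, such as piperidin-1-yl, or an open-chain group such as tert-butyl would hold the low number of compound 2 at this place.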